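Cyclobutylcarbonyl to propanoyl: a half-life estimate

A few compounds are considered here, and "the series" means these few. Any claim that something is new, unique, unknown or untested is made for them only; others in the source may bear on it.

Measured compounds:
compound 1 `CCn1c(-c2cnc(C)nc2)nc2c(N[C@H]3CCN(C(=O)C4CCC4)C3)ncnc21` — 1.3 h
compound 2 `CCn1c(-c2ccc(C(F)(F)F)nc2)nc2c(O[C@H]3CCN(C(=O)C4CCOC4)C3)ncnc21` — 3.6 h

Of the compounds shown here, two have been measured in an ADME assay (Canis lupus familiaris, strain Beagle) for metabolic stability; a lower number here means that the compound disappears faster, a higher number that the compound lasts longer. Compound 1 gives 1.3 h and stands lowest of the two numbers. Compound 2 differs from compound 1 in several places; compound 2 gives 3.6 h, a higher number, and the gap between the two lies beyond the usual scatter of this assay. Among the measured compounds shown here, no step between two compounds that differ in one place alone has been measured.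

Compound 3 `CCC(=O)N1CC[C@H](Nc2ncnc3c2nc(-c2cnc(C)nc2)n3CC)C1` is not yet measured. It differs from compound 1 in one place: ethyl in place of cyclobutyl on a carbonyl carbon. The amide nitrogen in the ring and the rest of the shared core are unchanged. For the measured compounds named here, because only compound 1 1.3 h offers a direct reference, and no measured pair shows what this change does, a step of no more than the scatter is expected, in either direction, so that no change at the digits printed from compound 1 to compound 3 (within the scatter) is the estimated step. For compound 3 a half-life of 1.3 h is estimated, in a range from 0.6 h to 2.8 h.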

Compound 3, half-life: 2.7 h
Beside the measured number, compound 3's estimate is 2.1-fold (0.32 log units) below it; the range from low to high includes it.
By their numbers in this assay, from the lowest: compound 1; then compounds 3 and 2 (each within the scatter of the next).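

In this assay, ethyl in place of cyclobutyl on a carbonyl carbon gives a 2.1-fold higher number from compound 1 to compound 3 (0.32 log units; beyond the scatter) with the shared core unchanged. This single-place step shows that the group on this carbonyl carbon can alter the half-life on its own, and that here the open ethyl chain, with no ring, outlasts the four-membered carbon ring. No measurement on hand accounts for the step.

Because this one change swaps a ring for a chain and also alters the number of heavy atoms, the compounds shown cannot separate the two, and a cyclopropyl or isopropyl group on the same carbonyl carbon would be needed to do so. As far as these compounds go, how a longer chain such as butyl, or an amine at this place, would fare in this assay also remains open.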